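A few compounds are considered here, and "the series" means these few. Any claim that something is new, unique, unknown or untested is made for them only; others in the source may bear on it.

Working notes on the series, read in a functional assay on RS4-11 cells (Homo sapiens) for inhibition, read by CCK-8 assay, with a stated time of 48 h; a higher number here means a weaker inhibitor, a lower number a stronger inhibitor.

Compound 1 `COc1ccc(Oc2ccccc2-c2ccsc2S(=O)(=O)N2CCN(C(=O)Nc3ccc([N+](=O)[O-])cc3)CC2)cc1OC` gives > 50000 nM in this assay, which is a limit of the assay and not a number. Compound 2 `COc1ccc(Oc2ccc([N+](=O)[O-])cc2-c2ccsc2S(=O)(=O)N2CCN(C(=S)Nc3ccc([N+](=O)[O-])cc3)CC2)cc1OC` likewise gives only > 50000 nM in this assay, again a limit. Two of the three measured entries therefore sit at the limit of > 50000 nM in this assay, at which 2 of the 3 values shown sit. Compound 3 `O=C(NCCNS(=O)(=O)c1ccc(-c2ccccc2Oc2ccc([N+](=O)[O-])c([N+](=O)[O-])c2)s1)Nc1cc(C(F)(F)F)cc(C(F)(F)F)c1` is the sole entry with a defined number, giving 2400 nM in this assay, and it is the only anchor available for judging the next compound.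

Compound 4 `Nc1ccc(Oc2ccccc2-c2ccc(S(=O)(=O)NCCNC(=O)Nc3cc(C(F)(F)F)cc(C(F)(F)F)c3)s2)cc1` has not yet been tested in this assay. Set against compound 3 it changes in a single place: 4-aminophenyl in place of 3,4-dinitrophenyl on an oxygen on an aromatic ring. Within the data shown here, no measured pair in the set varies this position, so neither the size nor the direction of the step can be read from the data; the expectation is a step of modest size, a 1.9-fold higher number from compound 3 to compound 4 (0.27 log units; within the scatter), toward somewhat weaker inhibition, not far beyond the usual scatter. Compound 4 is accordingly estimated at about 4500 nM in this assay, with a plausible range from 1200 nM to 20000 nM, the width of the range reflecting that only compound 3 supplies a number to build on.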

Compound 4, half-maximal inhibitory concentration: 11900 nM
Estimate against measurement, compound 4: 2.6-fold (0.42 log units) below; measured number inside the range.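

In this assay, among these compounds, replacing 3,4-dinitrophenyl with 4-aminophenyl on an oxygen on an aromatic ring gives the first measured step at this position: a 5.0-fold higher number from compound 3 to compound 4 (0.70 log units; beyond the scatter), toward weaker inhibition beyond the usual scatter. The position is therefore not indifferent to the group it carries, and compound 4 still gives a defined number of 11900 nM. Nothing measured for these compounds gives a cause for this step.

The single step removes the 3,4-dinitrophenyl group and brings in the 4-aminophenyl group as a whole, so the compounds shown leave open whether the loss of the nitro groups, the gain of the amine, or both account for the difference, a question that a plain phenyl or a 4-nitrophenyl group at this place would speak to. Among the compounds shown here, it also remains open whether a step of this size would hold with a 4-hydroxyphenyl or 4-carboxyphenyl group here, or with a different chain in place of the one shared by compound 3 and compound 4.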